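The source may hold more compounds than are shown below. What is called first, only, known or untested is meant among the compounds shown, and "the series" means these compounds.

Measured in a functional assay on HL-60 cells (Homo sapiens) for inhibition, read by CCK-8 assay, with a stated time of 48 h; a higher number here means a weaker inhibitor, a lower number a stronger inhibitor:
- compound 1 `Cc1cc(C)cc(NC(=O)NCCNS(=O)(=O)c2ccc(-c3ccccc3Oc3ccc([N+](=O)[O-])c([N+](=O)[O-])c3)s2)c1`: 9100 nM
- compound 2 `O=S(=O)(NCCNC(=S)Nc1cccc(Cl)c1)c1ccc(-c2ccccc2OCc2ccccc2)s1`: > 50000 nM (a limit)
- compound 3 `O=[N+]([O-])c1cccc(NC(=S)NCCNS(=O)(=O)c2ccc(-c3ccccc3OCc3ccccc3)s2)c1`: > 50000 nM (a limit)

Compound 3 has no numerical value, only the limit > 50000 nM. The series has a common ceiling, (the limit of > 50000 nM in this assay, at which 2 of the 3 values shown sit).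

The next compound is compound 4 `Cc1cc(C)cc(NC(=O)NCCNS(=O)(=O)c2ccc(-c3ccccc3OCc3ccccc3)s2)c1`, which keeps the core of compound 3 and changes one group on an amine nitrogen: a group of 11 heavy atoms (9 carbon, 1 nitrogen, 1 oxygen; one six-membered aromatic ring of carbon only) in place of a group of 12 heavy atoms (7 carbon, 2 nitrogen, 2 oxygen, 1 sulfur; one six-membered aromatic ring of carbon only), on an amine nitrogen. The entering group is (3,5-dimethylphenyl)carbamoyl.

Among the compounds with values here, the only step between measured compounds is a step that the two limits leave unreadable from compound 2 to compound 3. It involves nitro in place of chloro on an aromatic carbon and gives no size to carry over to this change. The closest guide is compound 1, which carries the same (3,5-dimethylphenyl)carbamoyl group but differs from compound 4 elsewhere on the core. Compound 1 gives 9100 nM, so the entering group is known to occur in a compound with a measurable value in this assay. That supports only a modest expectation of movement toward stronger inhibition, and a result at the limit remains quite possible.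

The expected change is an at least 1.6-fold lower number from compound 3 to compound 4 (0.22 log units; that floor lies within the scatter). Compound 4 is estimated at 30000 nM, with an expected range from 9000 nM to 50000 nM.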

Compound 4, half-maximal inhibitory concentration: 2200 nM
The estimate for compound 4 lay 14-fold (1.13 log units) above the measured number, and the stated range ends above it.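

In this assay, the (3,5-dimethylphenyl)carbamoyl group on the amine nitrogen brings the benzyl series off its ceiling, with an at least 22-fold lower number from compound 3 to compound 4 (1.35 log units; beyond the scatter) and an at least 22-fold lower number from compound 2 to compound 4 (1.35 log units; beyond the scatter). Both steps start from a limit of the assay and not from a number, so they give only a floor and their full size stays unknown: the limit of > 50000 nM in this assay, at which 2 of the 4 values shown sit.

With the (3,5-dimethylphenyl)carbamoyl group held in place, the other site also moves the number, with a 4.1-fold lower number from compound 1 to compound 4 (0.62 log units; beyond the scatter) for benzyl in place of 3,4-dinitrophenyl on an oxygen on an aromatic ring.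

The entering group differs from both leaving groups in two ways at once, the carbonyl in place of a thiocarbonyl and the ring substituents, so the compounds shown do not say which of the two carries the step. A (3,5-dimethylphenyl)thiocarbamoyl group or a plain phenylcarbamoyl group on the same amine nitrogen would separate these two contributions.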